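A few compounds are considered here, and "the series" means these few. Any claim that something is new, unique, unknown or untested is made for them only; others in the source may bear on it.

Measured so far:
compound 1, `COc1cc(/C(Cl)=C/C=C(\C#N)C(=O)c2c[nH]c3ccc(Br)cc23)cc(OC)c1OC`: 36.7%
compound 2, `COc1ccc(/C(Cl)=C/C=C(\C#N)C(=O)c2c[nH]c3ccccc23)cc1OC`: 75%

Of the compounds shown here, two have been measured in a functional assay for inhibition, read by Griess assay, with a stated time of 150 min, tested at 1 mM; a lower number here means less inhibition, a higher number more inhibition at the concentration tested (going by the name of the read-out). Compound 2, `COc1ccc(/C(Cl)=C/C=C(\C#N)C(=O)c2c[nH]c3ccccc23)cc1OC`, gives 75% in this assay, the higher of the two numbers. Compound 1, `COc1cc(/C(Cl)=C/C=C(\C#N)C(=O)c2c[nH]c3ccc(Br)cc23)cc(OC)c1OC`, gives 36.7% in this assay, a gap to compound 2 that lies beyond the scatter. Compound 1 and compound 2 differ in more than one place, so their two values alone do not show what any single change does.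

Compound 3, `COc1ccc(/C(Cl)=C/C=C(\C#N)C(=O)c2c[nH]c3ccc(Br)cc23)cc1OC`, has not yet been measured. It differs from compound 2 in one place: bromo in place of hydrogen on an aromatic carbon. Among the compounds with values here, no measured pair isolates this change, so the size of the step in this assay can only be guessed. A modest fall from compound 2 is expected, in the direction of compound 1 with its 36.7%, though a step within the scatter would not surprise. Compound 3 is therefore estimated at 55%, between 30% and 80%, a change from compound 2 to compound 3 of a number 20 percentage points lower from compound 2 to compound 3 (beyond the scatter).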

Compound 3, a percentage reported as inhibition, at one concentration (the size of the read-out at that concentration, not a potency): 57.5%
Compound 3: middle estimate off by 2.5 percentage points, on the low side; low and high end bracket the measured number.
By their numbers in this assay, from the lowest: compound 1; then compound 3; then compound 2.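

In this assay, bromo in place of hydrogen on an aromatic carbon of the six-membered aromatic ring of carbon only, part of a fused or bridged system of two rings, gives a number 17.5 percentage points lower from compound 2 to compound 3 (beyond the scatter) with nothing else altered, so this one change can now be read on its own. Within the data shown here, the new compound also gives the first clean reading of a second change: hydrogen in place of methoxy on an aromatic carbon gives a number 20.8 percentage points higher from compound 1 to compound 3 (beyond the scatter) in the same assay, which joins compound 1 and compound 2, two compounds that differ in more than one place, through two single steps that run in opposite directions along the chain. Nothing available explains why either step has the size it has.

Going by these compounds, at the bromo position, only hydrogen and bromo can be compared, so it remains open whether fluoro, an amine or a carboxylic acid on that carbon would lower the number as bromo does, or leave it unchanged. On these data alone, for the methoxy position, it also remains open whether a hydroxyl group or a longer chain such as ethoxy would give a number closer to that of compound 1 or to that of compound 3.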